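A Methyl-Oxadiazole in Place of a Hydroxyethyl-Triazole

A few compounds are considered here, and "the series" means these few. Any claim that something is new, unique, unknown or untested is made for them only; others in the source may bear on it.

Of the compounds shown here, three built on one shared core have been tested in a functional assay on HL-60 cells (Homo sapiens) for inhibition, read by MTT assay, with a stated time of 72 h; a higher number here means a weaker inhibitor, a lower number a stronger inhibitor. Compound 1 `Cc1ccc(-c2cn(-c3ccc(CN4CCN(C)CC4)cc3)nn2)cc1Nc1nccc(-c2cccnc2)n1` gives 6740 nM in this assay. Compound 2 `Cc1ccc(-n2cc(-c3cc(C(F)(F)F)cc(C(F)(F)F)c3)nn2)cc1Nc1nccc(-c2cccnc2)n1` gives 1600 nM. Compound 3 `Cc1ccc(-n2cc(C(C)O)nn2)cc1Nc1nccc(-c2cccnc2)n1` gives 25500 nM, the highest number of the three; the gap to compound 1 lies beyond the scatter, and the gap to compound 2 is wider still, so compound 3 is the weakest inhibitor among the measured compounds.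

Compound 4 `Cc1nnc(-c2ccc(C)c(Nc3nccc(-c4cccnc4)n3)c2)o1` has not yet been measured. It differs from compound 3 in one place: 5-methyl-1,3,4-oxadiazol-2-yl in place of 4-(1-hydroxyethyl)-1H-1,2,3-triazol-1-yl on an aromatic carbon. Among the compounds with values here, no measured pair shows this same exchange, so its effect cannot be read from the data; all that is seen is that compound 1 and compound 2, which lack the 1-hydroxyethyl group, both give lower numbers than compound 3. For compound 4 the expected step of a 2.8-fold lower number from compound 3 to compound 4 (0.45 log units; beyond the scatter) is toward a lower number, of modest size, near the edge of the scatter. The estimate for compound 4 is 9000 nM, with a range from 2000 nM to 40000 nM.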

Compound 4, half-maximal inhibitory concentration: > 30000 nM
Compound 4 was reported as a limit (the forecaster's own chance of this, stated with the estimate: 10%); middle value at least 3.3-fold (0.52 log units) from the limit.
By their numbers in this assay, from the lowest: compound 2; then compound 1; then compound 3. At a limit, above all of these: compound 4.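

In this assay compound 4 gives > 30000 nM, which is a limit of the assay and not a number. The exchange of 4-(1-hydroxyethyl)-1H-1,2,3-triazol-1-yl for 5-methyl-1,3,4-oxadiazol-2-yl at this position gives an at least 1.1-fold higher number from compound 3 to compound 4 (0.07 log units; that floor lies within the scatter), so only a floor of the step is known, and that floor does not separate the two compounds. The entering group has no hydrogen-bond donor and no 1-hydroxyethyl group, and this exchange still brings no lower number, so losing that group does not on its own give a stronger inhibitor here.

From the compounds shown here alone, how far compound 4 lies beyond that floor remains open. Also open, going by these compounds, is how this assay would read if an amine, a carboxylic acid or a longer alkyl chain stood in place of the methyl group on the oxadiazole.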